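A few compounds are considered here, and "the series" means these few. Any claim that something is new, unique, unknown or untested is made for them only; others in the source may bear on it.

Going by the values given here, in an assay on isolated protein for inhibition of tyrosine-protein kinase receptor UFO (Homo sapiens), read by LC-MS (on this read-out higher numbers stand for weaker inhibition and lower numbers for stronger inhibition), compound 2 `Cc1cc(-c2c(C)nn(C)c2C)ccc1-c1nnc(N(C)Cc2ccc3nccn3c2)o1` gives 79.4 nM, the lowest of the two numbers measured so far; compound 1 `Cc1nn(C)c(C)c1-c1ccc(-c2nnc(N(C)Cc3ccc4nccn4c3)o2)cc1` gives 1260 nM. Among the compounds with values here, the single measured step, a 16-fold lower number from compound 1 to compound 2 (1.20 log units; beyond the scatter), puts a methyl on the same aromatic carbon that is changed again here. Within the data shown here, compound 3 `Cc1nn(C)c(C)c1-c1ccc(-c2nnc(N(C)Cc3ccc4nccn4c3)o2)c(C#N)c1` carries cyano in place of methyl on an aromatic carbon, a swap with no measured counterpart, so the step from compound 1 to compound 2 shows only that this carbon moves the number strongly. The step is expected at a 2.0-fold higher number from compound 2 to compound 3 (0.30 log units; within the scatter), with no firm direction. Compound 3 is estimated at 160 nM, within 40 nM to 650 nM.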

Compound 3, half-maximal inhibitory concentration: > 100000 nM
Compound 3: a limit, no number; the forecaster's own chance of this, stated with the estimate: 3%; middle value at least 620-fold (2.79 log units) from the limit.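

Compound 3 stands at a limit of the assay, not at a number: the limit of > 100000 nM in this assay, at which 1 of the 3 values shown sits. On this aromatic carbon, methyl gives a 16-fold lower number from compound 1 to compound 2 (1.20 log units; beyond the scatter), whereas cyano in place of hydrogen gives an at least 79-fold higher number from compound 1 to compound 3 (1.89 log units; beyond the scatter), and cyano in place of methyl gives an at least 1200-fold higher number from compound 2 to compound 3 (3.10 log units; beyond the scatter). The same position therefore moves the number in both directions depending on the group, which the earlier pair alone did not show.

On these data alone, whether chloro, methoxy or an amine on this carbon would follow methyl or cyano remains open.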